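Hydroxy to Methoxy: What Compound 3 May Show

The compounds below may be only part of what the source reports. "The series", "measured", "known", "first", "only" and "open" are said of these compounds alone.

In a functional assay on NCI-H460 cells (Homo sapiens) for inhibition, read by sulforhodamine B assay, with a stated time of 48 h (a higher number here means a weaker inhibitor of growth, a lower number a stronger inhibitor of growth), compound 1 `CCOC(=O)C1=C(C)NC(=S)NC1c1ccc(O)cc1` gives > 250 ug/mL, which is a limit of the assay and not a number. Compound 1 therefore stands at the limit of > 250 ug/mL in this assay, at which 1 of the 2 values shown sits. In this assay, compound 2 `CCOC(=O)C1=C(C)NC(=S)NC1c1ccc(O)c(OC)c1` gives 180 ug/mL.

Compound 3 `CCOC(=O)C1=C(C)NC(=S)NC1c1ccc(OC)cc1` has not yet been measured. It differs from compound 1 by methyl in place of hydrogen on an oxygen on an aromatic ring, with methyl in place of hydrogen on an oxygen on an aromatic ring, so that hydroxy becomes methoxy.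

For the measured compounds named here, the only measured step that bears on this change is an at least 1.3-fold lower number from compound 1 to compound 2 (0.14 log units; that floor lies within the scatter). That step also brings in methoxy, but as methoxy in place of hydrogen on an aromatic carbon, and compound 2 keeps the hydroxy of compound 1. It is therefore only an indirect guide. Given that small step, a shift towards a lower number is expected for compound 3, but none clearly beyond the scatter.

The expected change is an at least 1.2-fold lower number from compound 1 to compound 3 (0.09 log units; that floor lies within the scatter). For compound 3, the estimated value is 200 ug/mL, with an expected range of 110 ug/mL to 350 ug/mL.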

Compound 3, concentration for 50% growth inhibition: 31.4 ug/mL
The estimate for compound 3 lay 6.4-fold (0.80 log units) above the measured number, and the stated range ends above it.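

In this assay, methyl in place of hydrogen on the oxygen on the aromatic ring gives an at least 7.9-fold lower number from compound 1 to compound 3 (0.90 log units; beyond the scatter), and this oxygen thereby emerges as a place where the growth read-out responds clearly to a small change. The earlier step, an at least 1.3-fold lower number from compound 1 to compound 2 (0.14 log units; that floor lies within the scatter), kept the hydroxy and brought in methoxy on an aromatic carbon instead, so it said nothing about what happens when the hydrogen on this oxygen is replaced. From the compounds shown here alone, the true size of the new step remains unknown and only its floor can be read, because compound 1 stands at a limit of the assay rather than at a number: the limit of > 250 ug/mL in this assay, at which 1 of the 3 values shown sits.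

The compounds shown leave open whether the change depends on methyl itself or would hold for a longer chain on the same oxygen, such as ethyl or propyl. They also do not tell how an amine, a fluorine or a carboxylic acid would fare in place of the hydroxy, so a single step marks this position and no trend can yet be drawn from it.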